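Swapping the amine on a shared sulfamate core

The compounds below may be only part of what the source reports. "The series", "measured", "known", "first", "only" and "open" are said of these compounds alone.

Compound 1 `CN(C)CCN(CCN(C)C)c1ccc(C(=O)N2CCc3ccc(OS(N)(=O)=O)cc3C2)cc1` gives 15.9% in an assay on HEK293 cells for inhibition of Steryl-sulfatase (Homo sapiens), tested at 1 uM; a higher number here means a stronger effect of the compound at the concentration tested, a lower number a weaker effect. Among the measured compounds shown here, compound 2 `CC(C)CCN(CCC(C)C)c1ccc(C(=O)N2CCc3ccc(OS(N)(=O)=O)cc3C2)cc1` gives 90.8% in this assay, the highest of the two numbers so far; the only other value, that of compound 1, lies far lower. For the measured compounds named here, the single measured step, a number 74.9 percentage points higher from compound 1 to compound 2 (beyond the scatter), shows that the group on this aromatic carbon matters greatly. Compound 3 `CCN(Cc1cccnc1)c1ccc(C(=O)N2CCc3ccc(OS(N)(=O)=O)cc3C2)cc1` differs from compound 2 by ethyl((pyridin-3-yl)methyl)amino in place of diisopentylamino on an aromatic carbon. Going by the values given here, the one step that bears on it is the move from compound 1 to compound 2, which was large; compound 3 again removes diisopentylamino and again brings in an extra nitrogen, so a fall beyond the scatter is expected, though likely smaller than the earlier one since compound 1 and compound 3 carry different groups. The estimated step is a number 40.8 percentage points lower from compound 2 to compound 3 (beyond the scatter). Compound 3 is estimated at 50%, within 20% to 85%.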

Compound 3, a percentage reported as inhibition, at one concentration (the size of the read-out at that concentration, not a potency): 85.2%
For compound 3 the middle estimate is 35.2 percentage points below the measured one, and the stated range ends below it.
By their numbers in this assay, from the lowest: compound 1; then compounds 3 and 2 (each within the scatter of the next).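

The diisopentylamino group can give way to ethyl((pyridin-3-yl)methyl)amino at this position with only a number 5.6 percentage points lower from compound 2 to compound 3 (within the scatter), so neither the two branched chains nor the absence of a second nitrogen in the group is needed to keep the read-out high. Meanwhile, a number 69.3 percentage points higher from compound 1 to compound 3 (beyond the scatter) shows that a group with more than one nitrogen is not poor as such, and that the low number of compound 1 belongs to bis(2-(dimethylamino)ethyl)amino specifically, not to every group of this kind. Nothing available here explains why these groups give such different numbers.

Still open, on these data alone, is what the pyridine nitrogen contributes, which a benzyl(ethyl)amino group in the same place would test. Also open, as far as these compounds go, is whether a carboxylic acid on the amine chains would give a number as low as that of compound 1, and a single-concentration read-out cannot rank compound 2 and compound 3 by potency.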